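A Phenyl for a Methyl on the Ester Carbonyl

The source may report more compounds than this note shows. Statements on the series, on what has been measured and on what is new or still open speak of the compounds shown alone.

Among the compounds with values here, compound 2 `CC(=O)OCCOCN1c2ccccc2C(=O)N(Cc2ccccc2)S1(=O)=O` is the only compound here with a number rather than a limit: in a functional assay on HEL cells (Homo sapiens) (a higher number here means that more compound is tolerated, a lower number that less compound is tolerated), compound 2 gives 100 ug/mL. Compound 1 `O=C1c2ccccc2N(COCc2ccccc2)S(=O)(=O)N1Cc1ccccc1` gives > 50 ug/mL, which is a limit of the assay and not a number. Compound 3 `O=C(OCCOCN1c2ccccc2C(=O)N(Cc2ccccc2)S1(=O)=O)c1ccccc1` differs from compound 2 by phenyl in place of methyl on a carbonyl carbon. Within the data shown here, the one measured step, a step that the limit leaves unreadable from compound 1 to compound 2, cannot be sized because of the limit of > 50 ug/mL in this assay, at which 1 of the 2 values shown sits, so no measured step tells how this assay answers a change of this kind. Compound 3 is therefore expected to shift by a 1.1-fold lower number from compound 2 to compound 3 (0.05 log units; within the scatter), within the scatter, with an estimated value of 90 ug/mL and a range of 40 ug/mL to 200 ug/mL.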

Compound 3, half-maximal cytotoxic concentration: 17 ug/mL
The estimate for compound 3 lay 5.3-fold (0.72 log units) above the measured number; measured number below the stated range.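

Phenyl in place of methyl on the carbonyl carbon gives a 5.9-fold lower number from compound 2 to compound 3 (0.77 log units; beyond the scatter), so in this assay this end of the side chain does respond to a change, and less of the benzoyl ester is tolerated than of the acetyl ester. (Benzoyloxy)methyl in place of phenyl on the chain gives an at least 2.9-fold lower number from compound 1 to compound 3 (0.46 log units; beyond the scatter). That second step is a bound rather than a size because of a limit: the limit of > 50 ug/mL in this assay, at which 1 of the 3 values shown sits.

The compounds shown leave open whether any large group on this carbonyl carbon lowers the number, or only an aromatic ring. A cyclohexyl ring or a longer chain such as butyl would separate those two readings.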